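The source may hold more compounds than are shown below. What is called first, only, known or untested is meant among the compounds shown, and "the series" means these compounds.

Measured compounds:
Compound 1, `NS(=O)(=O)c1ccc(CNC(=O)c2ccccc2)cc1`: 2870 nM
Compound 2, `NS(=O)(=O)c1ccc(NC(=O)c2ccc(F)cc2)cc1`: 58600 nM

In an assay on isolated protein for inhibition of alkaline phosphatase, tissue-nonspecific isozyme (Bos taurus), read by chemiluminescence and spectrophotometry (a higher number here means a weaker inhibitor, a lower number a stronger inhibitor), compound 1 holds the lower of the two numbers; compound 2 sits higher by a gap that lies beyond the scatter. Compound 3, `NS(=O)(=O)c1ccc(CNC(=O)c2ccc(F)cc2)cc1`, differs from compound 1 by fluoro in place of hydrogen on an aromatic carbon. Among the measured compounds shown here, no measured pair shows this change on its own, so its size is unknown; the expectation is a step no larger than the scatter, in either direction. Compound 3 is therefore expected to give about 3000 nM, within 1000 nM to 9000 nM. That estimate means a step of a 1.0-fold higher number from compound 1 to compound 3 (0.02 log units; within the scatter).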

Compound 3, half-maximal inhibitory concentration: 613 nM
Beside the measured number, compound 3's estimate is 4.9-fold (0.69 log units) above it; the whole stated range lies above it.
By their numbers in this assay, from the lowest: compound 3; then compound 1; then compound 2.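

Among the compounds shown here, replacing hydrogen with fluoro on this aromatic carbon, para to a large group, gives a 4.7-fold lower number from compound 1 to compound 3 (0.67 log units; beyond the scatter) in this assay, a step that the earlier compounds could not show. This position on the core of compound 1 therefore responds to a single fluorine atom, and the phenyl ring need not stay unsubstituted for inhibition to be kept. Nothing given here explains the step.

From the compounds shown here alone, it remains open whether chloro, methoxy or an amine at this position would match fluoro. Going by these compounds, it also remains open whether fluoro on another carbon of this ring would give a similar step.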